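Cyano to methyl on selenium

The source may report more compounds than this note shows. Statements on the series, on what has been measured and on what is new or still open speak of the compounds shown alone.

Of the compounds shown here, three have been read so far: compound 1 (`COc1ccc(N(C)c2ccnc(Cl)n2)cc1OCCCBr`), compound 2 (`COc1ccc(N(C)c2cc(C)nc(C)n2)cc1`) and compound 3 (`Cc1cc(N(C)c2ccc([Se]C#N)cc2)nc(C)n1`). In a functional assay on HepG2 cells (Homo sapiens) for antiproliferative activity, read by MTT assay, with a stated time of 48 h (on this read-out higher numbers stand for weaker inhibition and lower numbers for stronger inhibition), compound 3 gives 155 nM, the lowest of the three numbers and beyond the scatter from both others. In the same read-out compound 2 gives 824 nM and compound 1 gives 1240 nM.

Next comes compound 4 (`C[Se]c1ccc(N(C)c2cc(C)nc(C)n2)cc1`), with methyl in place of cyano on a selenium.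

Among the measured compounds shown here, the one measured step that bears on this is a 5.3-fold lower number from compound 2 to compound 3 (0.73 log units; beyond the scatter). It is modest, and it covers selenium and cyano together, so the data do not separate their shares. For the measured compounds named here, compound 1 differs from the others in more than one place and supplies no step. Compound 4 keeps the selenium of compound 3 but, like compound 2 at 824 nM, carries a terminal methyl, so a partial return towards that number is expected in this assay. The expected change is a 2.3-fold higher number from compound 3 to compound 4 (0.35 log units; beyond the scatter), a modest rise with an uncertain size. Compound 4 is estimated at 350 nM, with an expected range from 110 nM to 1000 nM.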

Compound 4, half-maximal inhibitory concentration: 198 nM
Beside the measured number, compound 4's estimate is 1.8-fold (0.25 log units) above it; the range from low to high includes it.
By their numbers in this assay, from the lowest: compounds 3 and 4 (each within the scatter of the next); then compounds 2 and 1 (each within the scatter of the next).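

In this assay, methyl in place of cyano on a selenium gives a 1.3-fold higher number from compound 3 to compound 4 (0.11 log units; within the scatter), so among these compounds the cyano is not required for a number in this range. Compound 2 and compound 4 also differ in one place, a group holding selenium and carbon in place of one holding oxygen and carbon, and that change gives a 4.2-fold lower number from compound 2 to compound 4 (0.62 log units; beyond the scatter). This separates what the earlier step, a 5.3-fold lower number from compound 2 to compound 3 (0.73 log units; beyond the scatter), left joined: the lower number goes with the selenium and remains when the cyano is gone, although this rests on a single pair of compounds in one cell line. Nothing on hand explains why the selenium compounds give lower numbers here.

Going by these compounds, it remains open whether larger groups on the selenium, such as an ethyl or a benzyl group, or a polar one such as an amine-bearing chain, would keep the number of compound 4 in this assay. On these data alone, it is equally open whether sulfur in place of the selenium would hold it, which would show whether the effect is specific to selenium.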